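Shifting the Methoxyphenyl Substituent on the Amine Nitrogen

This account rests on a few compounds, and the source may have more. Where it says the series, first, only, none or still open, it means among the compounds named here.

Compound 1 `COc1cccc(NC2=CC(=O)c3nc4n(c3C2=O)[C@H]2OC[C@@H](O)[C@H]2OC4)c1` carries a 3-methoxyphenyl on an amine nitrogen of the shared core. In a functional assay on MCF7 cells (Homo sapiens) for inhibition, read by sulforhodamine B assay (a higher number here means a weaker inhibitor, a lower number a stronger inhibitor), compound 1 gives > 4000 nM, which is a limit of the assay and not a number. For the measured compounds named here, compound 2 `O=C1C(NC2CCCCC2)=CC(=O)c2c1nc1n2[C@H]2OC[C@@H](O)[C@H]2OC1` is the only other compound measured here. In this assay compound 2 gives > 16000 nM, again only a limit. Compound 1 thus stands at one of two limits, with no numbered value to rank it against. Compound 3 `COc1ccccc1NC1=CC(=O)c2nc3n(c2C1=O)[C@H]1OC[C@@H](O)[C@H]1OC3` differs from compound 1 by 2-methoxyphenyl in place of 3-methoxyphenyl on an amine nitrogen. Going by the values given here, no measured step of this kind exists, and no change beyond the scatter is expected. Compound 3 is expected to give about 8000 nM, within 2000 nM to 40000 nM, in this assay. The expected step that the limit leaves unreadable from compound 1 to compound 3 is essentially none.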

Compound 3, half-maximal inhibitory concentration: > 4000 nM
Compound 3: a limit, no number; the forecaster's own chance of this, stated with the estimate: 70%; the middle value does not contradict the limit.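

The step between compound 1 and compound 3 cannot be read, because both stop at a limit and not at a number: the limit of > 4000 nM in this assay, at which 2 of the 3 values shown sit.

On these data alone, whether 2-methoxyphenyl and 3-methoxyphenyl differ at all in this assay stays open, since neither compound has a numbered value here.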